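Double-Bond Configuration in a Nitro Compound

The source may hold more compounds than are shown below. What is called first, only, known or untested is meant among the compounds shown, and "the series" means these compounds.

Measured in a functional assay on P388 cells (Mus musculus) for inhibition; on this read-out lower numbers stand for stronger inhibition and higher numbers for weaker inhibition:
- compound 1 `COCCOc1cc(/C=C/c2ccc3ccccc3c2)ccc1OC`: 2990 nM
- compound 2 `COCCOc1cc(/C=C\c2ccc3ccccc3c2)ccc1OC`: 2990 nM
- compound 3 `COc1ccc(/C=C/c2ccc3ccccc3c2)cc1[N+](=O)[O-]`: > 5000 nM

Compound 3 gives > 5000 nM, which is a limit of the assay and not a number. Its place relative to the 2-methoxyethoxy compound rests on an at least 1.6-fold higher number from compound 1 to compound 3 (0.22 log units; that floor lies within the scatter), so the two cannot be firmly ordered.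

Compound 4 `COc1ccc(/C=C\c2ccc3ccccc3c2)cc1[N+](=O)[O-]` is the partner of compound 3: the two compounds have the same atoms and bonds and differ only in configuration as drawn: 1 of 1 stereo elements differ; a double bond is drawn E in compound 3 and Z in compound 4. One measured step is of the same kind, and it shows no change at the digits printed from compound 1 to compound 2 (within the scatter). That is a single pair carrying 2-methoxyethoxy rather than nitro, so it is only a modest guide. The step with nitro in place of 2-methoxyethoxy involves no change of configuration and says little here beyond where compound 3 stands.

On the evidence of compound 2, no change beyond the scatter is expected in this assay, in either direction. The expected step is a step that the limit leaves unreadable from compound 3 to compound 4. Compound 4 may also be reported only as a limit. For compound 4 the estimated value is 6000 nM, with an expected range of 2500 nM to 15000 nM.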

Compound 4, half-maximal inhibitory concentration: > 20000 nM
Compound 4 was reported as a limit; the forecaster's own chance of this, stated with the estimate: 60%; middle value at least 3.3-fold (0.52 log units) away from the limit.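

Nitro in place of 2-methoxyethoxy on an aromatic carbon now has a firm result in this assay: the read-out shows an at least 6.6-fold higher number from compound 2 to compound 4 (0.82 log units; beyond the scatter). With the double bond drawn E, the same change had left compound 1 and compound 3 without a firm order, so the Z pair gives the first clear sign that nitro at this position goes with weaker inhibition than 2-methoxyethoxy. The change can now be compared on two cores: the same change on two cores in this assay, an at least 1.6-fold higher number (0.22 log units; that floor lies within the scatter) from compound 1 to compound 3 and an at least 6.6-fold higher number (0.82 log units; beyond the scatter) from compound 2 to compound 4; the limit leaves it open whether they differ

Compound 3 and compound 4 are both reported only as limits of the assay, and the step between them cannot be read. As far as these compounds go, whether double-bond configuration matters in the nitro pair therefore stays open, as does how an amine or a carboxylic acid at this position would read in this assay.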